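A new group on the amide-type nitrogen

A few compounds are considered here, and "the series" means these few. Any claim that something is new, unique, unknown or untested is made for them only; others in the source may bear on it.

Compound 1 `COc1cc(NC(=O)Nc2cccc3c(Nc4cc(OC)cc(OC)c4)ncnc23)cc(OC)c1` gives 366 nM
Compound 2 `COc1cc(Nc2ncnc3c(NC(=O)Nc4cc(C)cc(C)c4)cccc23)cc(OC)c1` gives 10100 nM

In a functional assay on RT-112 cells (Homo sapiens) for antiproliferative activity, read by MTT assay, with a stated time of 72 h (a higher number here means a weaker inhibitor of growth, a lower number a stronger inhibitor of growth), compound 2 stands highest of the two at 10100 nM and is the weaker inhibitor of growth. Compound 3 `COc1cc(Nc2ncnc3c(NC(=O)Nc4cccc(C(F)(F)F)c4F)cccc23)cc(OC)c1` changes one group on the amide-type nitrogen (2-fluoro-3-(trifluoromethyl)phenyl in place of 3,5-dimethylphenyl on an amide-type nitrogen). Among the compounds with values here, the only measured step at this place (a 28-fold higher number from compound 1 to compound 2 (1.44 log units; beyond the scatter)) was large, so a sizeable change is plausible here. Within the data shown here, no measured compound carries the entering group, so the direction is uncertain. Compound 2 (10100 nM) already sits at the top of the measured values, so a moderate fall is the more likely outcome. The expected step is a fall (a 3.4-fold lower number from compound 2 to compound 3 (0.53 log units; beyond the scatter)). In this assay compound 3 is estimated at 3000 nM (expected range 500 nM to 12000 nM).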

Compound 3, concentration for 50% growth inhibition: 471 nM
Estimate against measurement, compound 3: 6.4-fold (0.80 log units) above; measured number outside the range, below it.
By their numbers in this assay, from the lowest: compounds 1 and 3 (each within the scatter of the next); then compound 2.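

The amide-type nitrogen does not lose activity with every change away from 3,5-dimethoxyphenyl: 2-fluoro-3-(trifluoromethyl)phenyl in place of 3,5-dimethylphenyl recovers the loss (a 21-fold lower number from compound 2 to compound 3 (1.33 log units; beyond the scatter)). Set against 3,5-dimethoxyphenyl, the same group shows no real difference (a 1.3-fold higher number from compound 1 to compound 3 (0.11 log units; within the scatter)), so 3,5-dimethylphenyl alone stands apart among these three groups. No measurement here gives a reason for this.

From the compounds shown here alone, the fluorine and the trifluoromethyl group always appear together, so their separate contributions remain unknown. Going by these compounds, how an unsubstituted phenyl ring, a ring carrying an amine, or a longer alkyl chain would fare at this nitrogen also remains open.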